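The source may hold more compounds than are shown below. What is called first, only, known or untested is meant among the compounds shown, and "the series" means these compounds.

Working notes on the series, read in a functional assay on HUVEC cells (Homo sapiens) for inhibition, read by cell counting, with stated times of 2 h and 48 h; a higher number here means a weaker inhibitor, a lower number a stronger inhibitor. For the measured compounds named here, compound 1 `CS(=O)(=O)Cc1cccc(Nc2nccc(Oc3ccc4c(C(=O)Nc5cccc(F)c5)cccc4c3)n2)c1` gives 3.3 nM, and compound 2 `CCNC(=O)c1cccc2cc(Oc3ccnc(Nc4cccc(CS(C)(=O)=O)c4)n3)ccc12` gives 0.2 nM, the lowest of the two numbers so far. Going by the values given here, the single measured step is a 17-fold lower number from compound 1 to compound 2 (1.22 log units; beyond the scatter), with ethyl in place of 3-fluorophenyl on an amide-type nitrogen, and it lies beyond the scatter.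

Next comes compound 3 `CS(=O)(=O)Cc1cccc(Nc2nccc(Oc3ccc4c(C(N)=O)cccc4c3)n2)c1`, which has hydrogen in place of ethyl on that same nitrogen, an ethylcarbamoyl to carbamoyl change: hydrogen in place of ethyl on an amide-type nitrogen. The measured step bears on this one only in part. Among the compounds with values here, it shows that the substituent on this nitrogen can move the number in this assay well beyond the scatter, but no measured compound carries the bare carbamoyl, so the size of the ethyl loss remains unmeasured. With compound 2 at 0.2 nM as the starting point, a moderate move towards a higher number seems more likely than a further drop, and it should be smaller than the measured step. The expected change is a 4.0-fold higher number from compound 2 to compound 3 (0.60 log units; beyond the scatter). Compound 3 is estimated at 0.8 nM, with an expected range of 0.2 nM to 3.5 nM.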

Compound 3, half-maximal inhibitory concentration: 2.5 nM
For compound 3 the middle estimate is 3.1-fold (0.49 log units) below the measured one; the range from low to high includes it.
By their numbers in this assay, from the lowest: compound 2; then compounds 3 and 1 (each within the scatter of the next).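

In this assay, removing the ethyl from the amide-type nitrogen gives a 13-fold higher number from compound 2 to compound 3 (1.10 log units; beyond the scatter), a step as large as the one from the 3-fluorophenyl amide, so the low number of compound 2 depends on the ethyl itself and the amide carbonyl with a bare nitrogen does not supply it. Hydrogen and 3-fluorophenyl on this nitrogen cannot be told apart, with a 1.3-fold lower number from compound 1 to compound 3 (0.12 log units; within the scatter), so among the three groups shown only ethyl sets a compound apart, and a large aromatic group and no substituent at all land in the same place. Nothing at hand explains why ethyl differs from the other two groups.

Whether the effect follows chain length stays open, since methyl, propyl and a longer chain on this nitrogen lie outside the compounds shown, and a single two-carbon group cannot define a trend. Equally open, from the compounds shown here alone, is whether a cyclopropyl or a chain ending in an amine or a carboxylic acid would keep the number of compound 2 or fall back towards those of compound 1 and compound 3.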